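This account rests on a few compounds, and the source may have more. Where it says the series, first, only, none or still open, it means among the compounds named here.

The compounds measured so far in a functional assay on SK-MEL-28 cells (Homo sapiens) for inhibition; on this read-out higher numbers stand for weaker inhibition of growth and lower numbers for stronger inhibition of growth:
Compound 1, `COc1cc(/C=C/C(=O)c2cccc(-n3cc(-c4ccc(Cl)cc4)[nH]c3=O)c2)ccc1O`, gives 2060 nM.
Compound 2, `COc1cc(/C=C/C(=O)c2cccc(-n3cc(-c4ccccc4)[nH]c3=O)c2)cc(OC)c1OC`, gives 1740 nM.
Compound 3, `O=C(/C=C/c1cccc(O)c1)c1cccc(-n2cc(-c3ccc(Cl)cc3)[nH]c2=O)c1`, gives 3640 nM.

Compound 1 stands second highest of these three numbers. Its nearest neighbour is compound 2 and its furthest is compound 3, yet both gaps lie within the scatter, so the three measured compounds cannot be ranked against one another on this read-out.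

Compound 4, `COc1ccc(-c2cn(-c3cccc(C(=O)/C=C/c4ccc(O)c(OC)c4)c3)c(=O)[nH]2)cc1`, has not been measured. It differs from compound 1 in a single place: methoxy in place of chloro on an aromatic carbon. Within the data shown here, only one measured step concerns a single change, a 1.8-fold higher number from compound 1 to compound 3 (0.25 log units; within the scatter), and that step alters the chain end, not the six-membered aromatic ring of carbon only that carries the chloro. Compound 2 bears neither chloro nor methoxy on that ring and also a different chain end, so its value set against that of compound 1 shows only that the two sit within the scatter of each other. Among the measured compounds shown here, no measured pair speaks to methoxy in place of chloro. The expectation for this assay is therefore a step of no size beyond the scatter, in no particular direction, and compound 4 is expected to show a 1.1-fold higher number from compound 1 to compound 4 (0.03 log units; within the scatter). Compound 4 is estimated at 2200 nM, with a range from 900 nM to 5500 nM.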

Compound 4, concentration for 50% growth inhibition: 2030 nM
For compound 4 the middle estimate is 1.1-fold (0.03 log units) above the measured one; the measured number falls inside the stated range.
By their numbers in this assay, from the lowest: compounds 2, 4, 1 and 3 (each within the scatter of the next, the first and the last beyond it).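

In this assay, among these compounds, the change from 4-chlorophenyl to 4-methoxyphenyl comes with a 1.0-fold lower number from compound 1 to compound 4 (0.01 log units; within the scatter) and is the first measured step at this aromatic carbon, para to a large group, since the earlier step concerned the chain end. At this position, then, one chlorine can give way to the two heavy atoms of methoxy, with its one hydrogen-bond acceptor, and the number for growth inhibition stays within the scatter, at least with the 4-hydroxy-3-methoxyphenyl chain end of this pair. No measurement to hand accounts for this similarity, so the result describes the outcome of the change and gives no reason for it.

This single pair leaves open whether the same holds with another chain end, such as the 3-hydroxyphenyl group of compound 3, where the effect of methoxy in place of chloro has no reading. It also leaves open whether an amine, a carboxylic acid or a longer alkoxy chain such as butoxy on this same aromatic carbon would stay within the scatter or produce a step beyond it.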